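Trifluoromethoxy for trifluoromethyl on the shared core

The compounds below may be only part of what the source reports. "The series", "measured", "known", "first", "only" and "open" are said of these compounds alone.

Compound 2 `Oc1ccccc1-c1cc(-c2ccc(C(F)(F)F)cc2)cc(-c2ccccc2O)n1` is one of two members of the series measured so far. In a functional assay on HCT-15 cells (Homo sapiens) for inhibition (on this read-out lower numbers stand for stronger inhibition and higher numbers for weaker inhibition), compound 2 gives > 50000 nM, which is a limit of the assay and not a number. Compound 1 `Oc1ccccc1-c1cc(-c2ccc(F)cc2)cc(-c2ccccc2O)n1` likewise gives only a limit in this assay, namely > 50000 nM. The step that the two limits leave unreadable from compound 1 to compound 2 is therefore unreadable, as both values sit at the limit of > 50000 nM in this assay, at which 2 of the 2 values shown sit.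

Compound 3 `Oc1ccccc1-c1cc(-c2ccc(OC(F)(F)F)cc2)cc(-c2ccccc2O)n1` differs from compound 2 by trifluoromethoxy in place of trifluoromethyl on an aromatic carbon, on an aromatic carbon of a six-membered aromatic ring of carbon only, para to a large group. Within the data shown here, the only measured step, a step that the two limits leave unreadable from compound 1 to compound 2, also exchanges one fluorinated group for another at this same carbon and shows no readable size, so it gives no direction for the present change; no other step bears on it. The expectation in this assay is therefore no movement beyond the scatter, and most likely a value again reported only as a limit. Compound 3 is estimated at 80000 nM, with a range from 30000 nM to 300000 nM. The expected step that the limit leaves unreadable from compound 2 to compound 3 is thus essentially nil.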

Compound 3, half-maximal inhibitory concentration: > 50000 nM
Compound 3 gave a limit, no number; the forecaster's own chance of this, stated with the estimate: 85%; the middle value lies beyond the limit too.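

In this assay compound 3 gives only a limit, so no step among compound 1, compound 2 and compound 3 can be read, because all three stop at the same limit: the limit of > 50000 nM in this assay, at which 3 of the 3 values shown sit.

The compounds shown leave open whether any group at this aromatic carbon of the shared core gives a measurable value in this assay.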